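The source may report more compounds than this note shows. Statements on the series, on what has been measured and on what is new or still open speak of the compounds shown alone.

Going by the values given here, compound 1 `Oc1nc2nonc2nc1Nc1ccc(S(F)(F)(F)(F)F)cc1` stands with the lowest of the two numbers so far: in an assay on mitochondria from L6 cells (Rattus norvegicus) for activation, with a stated time of 90 min (on this read-out lower numbers stand for an effect already at smaller amounts and higher numbers for an effect only at larger amounts of compound), compound 1 gives 3900 nM, while compound 2 `Oc1nc2nonc2nc1Nc1cccc2ccccc12` gives 20400 nM in this assay, a higher number beyond the scatter. Compound 3 `Oc1nc2nonc2nc1Nc1ccc(F)cc1` differs from compound 1 only by one fluorine atom in place of a group of 6 heavy atoms (5 fluorine, 1 sulfur; no ring), on an aromatic carbon. Among the compounds with values here, no pair of measured compounds isolates this change, so nothing measured sets its size. For compound 3 an effect only at larger amounts than compound 1 is expected, a step of a 3.1-fold higher number from compound 1 to compound 3 (0.49 log units; beyond the scatter), beyond the scatter. In this assay compound 3 is estimated at 12000 nM, between 3500 nM and 40000 nM.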

Compound 3, half-maximal effective concentration: 38600 nM
Compound 3: the middle estimate sits 3.2-fold (0.51 log units) below what was measured; the range from low to high includes it.
By their numbers in this assay, from the lowest: compound 1; then compounds 2 and 3 (each within the scatter of the next).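

In this assay, going by these compounds alone, fluoro in place of the group of 6 heavy atoms (5 fluorine, 1 sulfur) gives a 9.9-fold higher number from compound 1 to compound 3 (1.00 log units; beyond the scatter) and is the first measured size for a change at this aromatic carbon. The number here therefore depends on the group carried at this position, and in this single pair the larger group goes with the lower number. No measurement at hand bears on what underlies this step.

Where a trifluoromethyl group or a methoxy group at this aromatic carbon would fall remains open. So does whether the numbers follow the size of the group across further members of the series.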